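The compounds below may be only part of what the source reports. "The series", "measured", "known", "first", "only" and "open" are said of these compounds alone.

Values so far in a toxicity assay on HepG2 cells (Homo sapiens) for inhibition, read by resazurin assay, with a stated time of 24 h (a lower number here means that less compound is tolerated, a higher number that more compound is tolerated), each of them a limit of the assay and not a number:

- Compound 1 (`CC(NC(=O)c1ncc([N+](=O)[O-])n1C)c1ccc(F)cc1`): > 100000 nM
- Compound 2 (`CN(C)C(=O)c1ncc([N+](=O)[O-])n1C`): > 100000 nM
- Compound 3 (`CN(C)C(=O)c1ncc([N+](=O)[O-])[nH]1`): > 100000 nM

Compound 4 (`CNC(=O)c1ncc([N+](=O)[O-])[nH]1`) has not yet been measured.

Compound 3 has no exact position on the scale, since it is known only as the limit > 100000 nM. It shares that position with the other two compounds, as the record reads (the limit of > 100000 nM in this assay, at which 3 of the 3 values shown sit).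

The step to compound 4 places hydrogen in place of methyl on an amide-type nitrogen, dimethylamino to methylamino: hydrogen in place of methyl on an amide-type nitrogen. For the measured compounds named here, the only measured step of a similar kind is a step that the two limits leave unreadable from compound 2 to compound 3. That change is hydrogen in place of methyl on an aromatic nitrogen, so it sits elsewhere on the molecule and gives no size to carry over.

The expectation therefore rests on compound 1, compound 2 and compound 3 together, with the limit of > 100000 nM in this assay, at which 3 of the 3 values shown sit. No change beyond the scatter is expected in this assay, and no direction can be argued, so a reading at the same limit is the likeliest outcome. The expected change is a step that the limit leaves unreadable from compound 3 to compound 4. For compound 4 the estimated half-maximal cytotoxic concentration is 120000 nM, with an expected range of 60000 nM to 250000 nM.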

Compound 4, half-maximal cytotoxic concentration: > 100000 nM
Compound 4 was reported as a limit (the forecaster's own chance of this, stated with the estimate: 85%); the middle value does not contradict the limit.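

In this assay compound 4 gives > 100000 nM, a limit of the assay and not a number. For the compounds shown here, compound 3 is also known only as a limit, so no step between compound 3 and compound 4 can be read. The compounds shown leave open at what concentration any of them would harm these cells, and they offer no ranking, since all share one position: the limit of > 100000 nM in this assay, at which 4 of the 4 values shown sit.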